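Aminomethyl on the shared core: solubility outlook

A few compounds are considered here, and "the series" means these few. Any claim that something is new, unique, unknown or untested is made for them only; others in the source may bear on it.

In a physicochemical assay for solubility, read by HPLC, using the shake flask method, in phosphate buffer, with a stated time of 20 h, at pH 6.5 (a higher number here means a more soluble compound, a lower number a less soluble compound), compound 1 (`NC1CCN(c2nccc3[nH]c(-c4cccc(OC(F)(F)F)c4)nc23)CC1`) gives 200000 nM and compound 2 (`CN(C)C1CCN(c2nccc3[nH]c(-c4cccc(OC(F)(F)F)c4)nc23)CC1`) gives 180000 nM while compound 3 (`CN1CCN(C2CCN(c3nccc4[nH]c(-c5cccc(OC(F)(F)F)c5)nc34)CC2)CC1`) gives 190000 nM so compound 3 stands level with both others within the scatter.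

Compound 4 (`NCC1CCN(c2nccc3[nH]c(-c4cccc(OC(F)(F)F)c4)nc23)CC1`) has aminomethyl in place of 4-methylpiperazin-1-yl on a saturated ring carbon and remains unmeasured. Within the data shown here, three measured steps bear on this change, and all stay within the scatter: dimethylamino in place of amino (a 1.1-fold lower number from compound 1 to compound 2 (0.05 log units; within the scatter)), 4-methylpiperazin-1-yl in place of amino (a 1.1-fold lower number from compound 1 to compound 3 (0.02 log units; within the scatter)) and 4-methylpiperazin-1-yl in place of dimethylamino (a 1.1-fold higher number from compound 2 to compound 3 (0.02 log units; within the scatter)). Among the measured compounds shown here, no measured compound yet carries aminomethyl, so the read-across rests on these three compounds alone.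

No step beyond the scatter is expected in this assay and no direction is favoured. The estimated step (no change at the digits printed from compound 3 to compound 4 (within the scatter)) is accordingly small. Compound 4 is expected at 190000 nM with an estimated range from 110000 nM to 240000 nM on present evidence.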

Compound 4, solubility: 200000 nM
For compound 4 the middle estimate is 1.1-fold (0.02 log units) below the measured one, and the stated range covers the measured number.
By their numbers in this assay, from the lowest: compounds 2, 3, 1 and 4 (each within the scatter of the next).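

In this assay the saturated ring carbon, three ring bonds from the ring nitrogen, now also accepts aminomethyl with no step beyond the scatter against any of the three earlier groups (a 1.1-fold higher number from compound 3 to compound 4 (0.02 log units; within the scatter)), (a 1.1-fold higher number from compound 2 to compound 4 (0.05 log units; within the scatter)) and (no change at the digits printed from compound 1 to compound 4 (within the scatter)). The change from 4-methylpiperazin-1-yl, with 7 heavy atoms and a ring, to aminomethyl, with 2 heavy atoms and no ring, leaves the read-out level, so across these four compounds neither the heavy-atom count nor the ring separates the numbers. No measurement at hand gives a reason for this level picture.

From the compounds shown here alone, all four compounds carry an amine at this place, so a carboxylic acid, an amide or an ether there remains open, as does a longer chain such as aminoethyl. Going by these compounds, whether a change elsewhere on the shared core would move this read-out also remains open.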